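This account rests on a few compounds, and the source may have more. Where it says the series, first, only, none or still open, it means among the compounds named here.

Compound 1 `O=C(c1ccc(F)c(F)c1)N1CC(c2nc(-c3cccc(F)c3)no2)C1` opens the series. In an assay on HEK293 cells for negative allosteric modulation of metabotropic glutamate receptor 5 (Homo sapiens), read by FLIPR (a higher number here means a weaker inhibitor, a lower number a stronger inhibitor), compound 1 gives only a limit, > 10000 nM. Compound 2 `COC1CCN(C(=O)N2CC(c3nc(-c4cccc(Cl)c4)no3)C2)CC1` shares the core of compound 1. In this assay compound 2 likewise gives only a limit, > 10000 nM. Among the compounds with values here, the measured values therefore amount to no more than the limit of > 10000 nM in this assay, at which 2 of the 2 values shown sit, and no measured step between compounds is available. Compound 3 `Cc1ccc(C(=O)N2CC(c3nc(-c4cccc(F)c4)no3)C2)cc1` differs from compound 1 by 4-methylphenyl in place of 3,4-difluorophenyl on a carbonyl carbon. With the known values at the limit, no step beyond the scatter is expected, and the expected step is a number no higher from compound 1 to compound 3 (the limit leaves the size open). For compound 3 the expected value in this assay is 10000 nM, within 3000 nM to 30000 nM.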

Compound 3, half-maximal inhibitory concentration: > 10000 nM
Compound 3: a limit, no number; the forecaster's own chance of this, stated with the estimate: 70%; the middle value lies on the limit itself.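

No step can be read from compound 1 to compound 3, because both results are limits and not numbers: the limit of > 10000 nM in this assay, at which 3 of the 3 values shown sit.

The compounds shown leave open whether any change on the shared core gives a measurable value in this assay.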